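From Hydroxy to Methoxy at the Edge of Measurement

The compounds below may be only part of what the source reports. "The series", "measured", "known", "first", "only" and "open" are said of these compounds alone.

Three related compounds have been tested so far. For the measured compounds named here, in a functional assay on NCI-H1975 cells (Homo sapiens) for cytotoxicity, read by CCK-8 assay, with a stated time of 24 h (a higher number here means a weaker inhibitor, a lower number a stronger inhibitor), compound 1 (`C=C[C@@]1(C)C=C(C)[C@@H]2[C@@H]3[C@H](Oc4ccc(cc4)C[C@@H]4C(=O)NC(=O)[C@@H]4C(=O)[C@H]31)[C@@H]1[C@@H](C)C[C@@H](C)C[C@]12C`) gives 75000 nM as the only true measured number of the three. Compound 2 (`CC(=O)[C@@H]1[C@@H]2[C@H](Oc3ccc(cc3)C[C@]3(O)C[C@]4(C[C@@H](O)[C@](C)(C=O)[C@@H]2C4=O)C(=O)N3)[C@@H]2[C@@H](C)C[C@@H](C)C[C@]21C`) reads > 80000 nM and this is a limit of the assay, not a number. Compound 3 (`C[C@@H]1C[C@H](C)[C@H]2[C@H]3Oc4ccc(cc4)C[C@]4(O)C[C@]5(C[C@H](O)OO[C@@]6(C)[C@H]7O[C@@]7(C)[C@H]([C@H]3[C@H]6C5=O)[C@]2(C)C1)C(=O)N4`) reads > 80000 nM and this too is only a limit. Compound 3 therefore stands with compound 2 at the limit of > 80000 nM in this assay, at which 2 of the 3 values shown sit, and neither has an exact figure.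

Compound 4 (`CO[C@@]12Cc3ccc(cc3)O[C@H]3[C@@H]4[C@H]5C(=O)[C@](C[C@H](O)OO[C@@]5(C)[C@H]5O[C@@]5(C)[C@H]4[C@]4(C)C[C@H](C)C[C@H](C)[C@@H]34)(C1)C(=O)N2`) has not been measured yet. It differs from compound 3 by a single change, hydroxy to methoxy, with methyl in place of hydrogen on an oxygen on a saturated carbon. Going by the values given here, no pair of tested compounds shows what this change does in this assay on its own. The expectation rests on compound 3 with its limit of > 80000 nM and no shift beyond the usual scatter is expected in either direction. The expected step is a step that the limit leaves unreadable from compound 3 to compound 4 and it should stay small. For compound 4 the estimate is 85000 nM with an expected range from 45000 nM to 150000 nM and the assay may well report only a limit again.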

Compound 4, half-maximal inhibitory concentration: > 80000 nM
Compound 4 was reported as a limit; the forecaster's own chance of this, stated with the estimate: 75%; the middle value lies beyond the limit too.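

For the compounds shown here, no step from compound 3 to compound 4 can be read, because both compounds are reported only as a limit and not as a number: the limit of > 80000 nM in this assay, at which 3 of the 4 values shown sit.

On these data alone, whether the change from hydroxy to methoxy alters cell-killing strength at all in this assay stays open, with no exact figure on either side of it.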